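Fluoro removal from the compound 2 aryl amide

This account rests on a few compounds, and the source may have more. Where it says the series, first, only, none or still open, it means among the compounds named here.

Measured in a functional assay on KYSE-70 cells for antiproliferative activity against KYSE-70 cell line (Homo sapiens), read by MTT assay, with a stated time of 72 h; on this read-out lower numbers stand for stronger inhibition and higher numbers for weaker inhibition:
- compound 1 `O=C(Nc1cccc(F)c1)c1cc(=O)[nH]c2cc(Br)ccc12`: 8900 nM
- compound 2 `O=C(Nc1cc(F)c(F)c(F)c1)c1cc(=O)[nH]c2cc(Br)ccc12`: > 20000 nM

Compound 2 has no numeric value: its > 20000 nM is a limit of the assay. Compound 3 `O=C(Nc1cc(F)cc(F)c1)c1cc(=O)[nH]c2cc(Br)ccc12` is the next case, with hydrogen in place of fluoro on an aromatic carbon, ortho to two fluoro groups and para to a large group in compound 2 (hydrogen in place of fluoro on an aromatic carbon). Among the measured compounds shown here, the only numeric reference is compound 1 at 8900 nM. A moderate shift towards stronger inhibition in this assay is expected, as the estimated step of an at least 1.6-fold lower number from compound 2 to compound 3 (0.22 log units; that floor lies within the scatter). For compound 3 the estimate is 12000 nM, with an expected range of 5500 nM to 20000 nM.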

Compound 3, half-maximal inhibitory concentration: 10700 nM
Estimate against measurement, compound 3: 1.1-fold (0.05 log units) above; the range from low to high includes it.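

In this assay, hydrogen in place of the fluoro ortho to two fluoro groups gives an at least 1.8-fold lower number from compound 2 to compound 3 (0.27 log units; that floor lies within the scatter), so this position has only a floor for its step, with no size fixed. Among the compounds shown here, the first numeric comparison concerns a second fluoro on the aryl amide, fluoro in place of hydrogen on an aromatic carbon, and it gives a 1.2-fold higher number from compound 1 to compound 3 (0.08 log units; within the scatter). Compound 2 carries a limit and not a number: the limit of > 20000 nM in this assay, at which 1 of the 3 values shown sits.

On these data alone, how far the number moves at this position with a methoxy, an amine or a carboxylic acid in place of fluoro remains open. As far as these compounds go, the size of the true step from the trifluoro aryl amide also remains open.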